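A few compounds are considered here, and "the series" means these few. Any claim that something is new, unique, unknown or untested is made for them only; others in the source may bear on it.

In a functional assay on HCT-116 cells (Homo sapiens) for antiproliferative activity, read by sulforhodamine B assay, with a stated time of 72 h (a lower number here means a stronger inhibitor, a higher number a weaker inhibitor), compound 1 `Cn1ncc(Cl)c1-c1cc(C(=O)N[C@@H]2CN[C@H](CCCO)C[C@H]2c2ccc(Cl)c(Cl)c2)oc1Cl` gives 510 nM and compound 2 `CCC[C@@H]1C[C@@H](c2ccc(Cl)c(Cl)c2)[C@H](NC(=O)c2cc(-c3c(Cl)cnn3C)c(Cl)o2)CN1` gives 1020 nM. Among the compounds with values here, these two values lie within the scatter of each other, so compound 2 sits level with its only measured neighbour. Compound 3 `Cn1ncc(Cl)c1-c1cc(C(=O)N[C@@H]2CN[C@H](CCN3CCCC3)C[C@H]2c2ccc(Cl)c(Cl)c2)oc1Cl` differs from compound 2 on a saturated chain carbon, two bonds along the chain from a saturated ring carbon: pyrrolidin-1-yl in place of methyl on a saturated chain carbon, two bonds along the chain from a saturated ring carbon. Within the data shown here, only one measured step bears on this change. That step, a 2.0-fold higher number from compound 1 to compound 2 (0.30 log units; within the scatter), put hydrogen in place of hydroxy on a saturated chain carbon and stayed within the scatter. Among the measured compounds shown here, no measured compound carries pyrrolidin-1-yl, so the data give no direction, and no step beyond the scatter is expected in this assay. The expected step is a 1.7-fold lower number from compound 2 to compound 3 (0.23 log units; within the scatter). For compound 3 the estimate is 600 nM, with an expected range from 200 nM to 1800 nM.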

Compound 3, half-maximal inhibitory concentration: 1940 nM
Estimate against measurement, compound 3: 3.2-fold (0.51 log units) below; the measured number lies above the stated range.
By their numbers in this assay, from the lowest: compounds 1, 2 and 3 (each within the scatter of the next, the first and the last beyond it).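

In this assay pyrrolidin-1-yl takes the place of methyl on the saturated chain carbon, bringing five heavy atoms and a five-membered non-aromatic ring to the chain, with a 1.9-fold higher number from compound 2 to compound 3 (0.28 log units; within the scatter) and so this larger ring-bearing group reads level with the propyl chain of compound 2. Set against the hydroxy-ended chain of compound 1, the same group gives a 3.8-fold higher number from compound 1 to compound 3 (0.58 log units; beyond the scatter) and this is the only step among the three compounds that passes beyond the scatter, and only modestly. Nothing measured here explains either step.

The compounds shown leave open whether an open-chain amine such as dimethylamino, a carboxylic acid or a longer chain ending in hydroxy would read closer to compound 1 or to compound 3. They also do not separate the ring from its nitrogen, which a cyclopentyl group on this chain would do.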